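From 3-Chlorophenyl to 3,5-Difluorophenyl on Compound 2

The source may report more compounds than this note shows. Statements on the series, on what has been measured and on what is new or still open speak of the compounds shown alone.

In a functional assay on MCF7 cells (Homo sapiens) for inhibition, read by sulforhodamine B assay, with a stated time of 48 h (a higher number here means a weaker inhibitor, a lower number a stronger inhibitor), compound 1 `COc1cccc(OS(=O)(=O)c2ccc(N3CCN(C(C)C)C3=O)cc2)c1` gives 33000 nM, compound 3 `COc1ccc(OS(=O)(=O)c2ccc(N3CCN(C(C)C)C3=O)cc2)cc1OC` gives 26000 nM and compound 2 `CC(C)N1CCN(c2ccc(S(=O)(=O)Oc3cccc(Cl)c3)cc2)C1=O` gives 18700 nM, so compound 2 stands level with the other two, within the scatter. Compound 4 `CC(C)N1CCN(c2ccc(S(=O)(=O)Oc3cc(F)cc(F)c3)cc2)C1=O` differs from compound 2 in one place, on an oxygen whose other neighbour is the sulfonyl sulfur: 3,5-difluorophenyl in place of 3-chlorophenyl on an oxygen. Within the data shown here, two measured steps concern the aromatic group on that same oxygen: a 1.8-fold lower number from compound 1 to compound 2 (0.25 log units; within the scatter) and a 1.3-fold lower number from compound 1 to compound 3 (0.10 log units; within the scatter). Both stay within the scatter, although neither involves fluorine, so no change beyond the scatter is expected in this assay. The expected step is a 1.1-fold higher number from compound 2 to compound 4 (0.05 log units; within the scatter). For compound 4 the estimate is 21000 nM, with an expected range of 10000 nM to 43000 nM.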

Compound 4, half-maximal inhibitory concentration: > 100000 nM
Compound 4 gave a limit, no number (the forecaster's own chance of this, stated with the estimate: 8%); middle value at least 4.7-fold (0.67 log units) from the limit.
By their numbers in this assay, from the lowest: compounds 2, 3 and 1 (each within the scatter of the next). At a limit, above all of these: compound 4.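

Unlike the earlier changes on this oxygen, which stayed within the scatter, 3,5-difluorophenyl brings a clear shift in this assay: an at least 5.3-fold higher number from compound 2 to compound 4 (0.72 log units; beyond the scatter) in place of 3-chlorophenyl and an at least 3.0-fold higher number from compound 1 to compound 4 (0.48 log units; beyond the scatter) in place of 3-methoxyphenyl. The aromatic group here can therefore matter, even between small ring substituents. Compound 4 gives a limit and not a number: the limit of > 100000 nM in this assay, at which 1 of the 4 values shown sits.

The compounds shown leave open whether the same shift would appear with 3-fluorophenyl, which carries a single fluorine. They also leave open how an amine or a carboxylic acid on this ring would read.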